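A few compounds are considered here, and "the series" means these few. Any claim that something is new, unique, unknown or untested is made for them only; others in the source may bear on it.

Compound 3 `C/C(=C\CC/C(C)=C/CC[C@@H]1[C@@]2(C)CCC(=O)C(C)(C)[C@H]2CC[C@@]1(C)O)CC/C=C(\C)C(=O)OCc1cn(-c2ccc(C)cc2)nn1` was tested in a functional assay on DU-145 cells (Homo sapiens) for antiproliferative activity, read by MTT assay, with a stated time of 48 h; a higher number here means a weaker inhibitor, a lower number a stronger inhibitor. Compound 3 gives only a limit of the assay there, > 150000 nM, not a number. Compound 1 `C/C(=C\CC/C(C)=C/CC[C@@H]1[C@@]2(C)CCC(=O)C(C)(C)[C@H]2CC[C@@]1(C)O)CC/C=C(\C)C(=O)OCc1cn(-c2ccc(F)c(Cl)c2)nn1` likewise returns only a limit, > 150000 nM. Compound 2 `C/C(=C\CC/C(C)=C/CC[C@@H]1[C@@]2(C)CCC(=O)C(C)(C)[C@H]2CC[C@@]1(C)O)CC/C=C(\C)C(=O)OCc1cn(-c2ccc(C(C)(C)C)cc2)nn1` also returns only a limit, > 150000 nM. The steps among these three, a step that the two limits leave unreadable from compound 1 to compound 2, a step that the two limits leave unreadable from compound 1 to compound 3 and a step that the two limits leave unreadable from compound 2 to compound 3, cannot be read, since the limit of > 150000 nM in this assay, at which 3 of the 3 values shown sit, gathers every value shown. Compound 4 `C/C(=C\CC/C(C)=C/CC[C@@H]1[C@@]2(C)CCC(=O)C(C)(C)[C@H]2CC[C@@]1(C)O)CC/C=C(\C)C(=O)OCc1cn(-c2cccc(C)c2)nn1` has not yet been measured; it differs from compound 3 by 3-methylphenyl in place of 4-methylphenyl on an aromatic nitrogen. For the measured compounds named here, none of the measured steps can show how such a change acts in this assay. For compound 4 the expected step is a step that the limit leaves unreadable from compound 3 to compound 4, with a strong chance that this assay again reports only a limit. The estimate for compound 4 is 200000 nM, from 80000 nM to 600000 nM.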

Compound 4, half-maximal inhibitory concentration: 137000 nM
Estimate against measurement, compound 4: 1.5-fold (0.16 log units) above; measured number inside the range.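

For the compounds shown here, compound 4 gives the first true number in this assay, so three steps now have a floor: an at least 1.0-fold lower number from compound 3 to compound 4 (0.03 log units; that floor lies within the scatter), an at least 1.0-fold lower number from compound 2 to compound 4 (0.03 log units; that floor lies within the scatter) and an at least 1.0-fold lower number from compound 1 to compound 4 (0.03 log units; that floor lies within the scatter). Each floor lies within the scatter, so 3-methylphenyl cannot yet be ranked above the other groups on the aromatic nitrogen. The steps among compound 1, compound 2 and compound 3 still cannot be read, since each of them sits at a limit: the limit of > 150000 nM in this assay, at which 3 of the 4 values shown sit.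

Still open, from the compounds shown here alone, is how an amine or a carboxylic acid in place of the methyl of 3-methylphenyl would act in this assay.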